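A few compounds are considered here, and "the series" means these few. Any claim that something is new, unique, unknown or untested is made for them only; others in the source may bear on it.

Measured compounds:
compound 1 `C[C@H](Nc1nc(N)nc(N)c1C#N)c1cc2ccc(F)cn2c(=O)c1-c1ccccc1` — 0.09 nM
compound 2 `C[C@H](Nc1nc(N)nc(N)c1C#N)c1cc(=O)n2cc(F)ccc2c1-c1cc(F)cc(F)c1` — 15.9 nM

In a functional assay on TMD8 cells (Homo sapiens) for inhibition, read by CellTiter-Glo and ATP content, with a stated time of 96 h (on this read-out lower numbers stand for stronger inhibition and higher numbers for weaker inhibition), compound 1 gives 0.09 nM, the lowest of the two numbers; compound 2 gives 15.9 nM, a gap beyond the scatter, though the two differ in more than one place, so only the two values themselves can be compared.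

Compound 3 `C[C@H](Nc1nc(N)nc(N)c1C#N)c1c(-c2ccccc2)c(=O)n2cc(F)ccc2c1-c1ccccc1` differs from compound 1 by phenyl in place of hydrogen on an aromatic carbon. Among the measured compounds shown here, no single-change step between measured compounds is available to anchor this. A moderate rise in the number is expected, a 6.7-fold higher number from compound 1 to compound 3 (0.82 log units; beyond the scatter), with wide uncertainty. Compound 3 is estimated at 0.6 nM, range 0.08 nM to 5 nM.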

Compound 3, half-maximal inhibitory concentration: 0.012 nM
Compound 3: the middle estimate sits 50-fold (1.70 log units) above what was measured, and the stated range ends above it.
By their numbers in this assay, from the lowest: compound 3; then compound 1; then compound 2.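

In this assay, phenyl in place of hydrogen on this aromatic carbon gives a 7.5-fold lower number from compound 1 to compound 3 (0.88 log units; beyond the scatter), so this position, two atoms from the ring nitrogen, accepts a group of 6 heavy atoms with a gain in inhibition. Among the compounds shown here, this is the first single-place step. No measurement at hand accounts for the gain.

From the compounds shown here alone, whether a smaller methyl, an amine or a carboxylic acid on this carbon would give a similar number remains open. Also open, going by these compounds, is whether phenyl here has the same effect on compound 2.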